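A Methyl Group Added to Compound 2

This account rests on a few compounds, and the source may have more. Where it says the series, first, only, none or still open, it means among the compounds named here.

In a functional assay on NCI-H661 cells (Homo sapiens) for antiproliferative activity, read by MTT assay, with a stated time of 72 h (on this read-out lower numbers stand for stronger inhibition and higher numbers for weaker inhibition), compound 1 (`Cc1ccc(-c2noc(CCCCCCC(=O)NO)n2)cc1`) gives 15800 nM and compound 2 (`Nc1ccccc1NC(=O)CCCCCCc1nc(-c2ccccc2)no1`) gives 960 nM. Compound 2 therefore holds the lower of the two numbers, and the gap between them lies beyond the scatter. Compound 3 (`Cc1ccc(-c2noc(CCCCCCC(=O)Nc3ccccc3N)n2)cc1`) replaces hydrogen with methyl on an aromatic carbon of compound 2, para to a large group: methyl in place of hydrogen on an aromatic carbon. For the measured compounds named here, no measured pair shows this change alone. In this assay, the expected result is no step beyond the scatter: the estimated 1.1-fold higher number from compound 2 to compound 3 (0.06 log units; within the scatter) is small. For compound 3, the expected value is 1100 nM, within an estimated range of 450 nM to 2700 nM.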

Compound 3, half-maximal inhibitory concentration: 410 nM
Compound 3: middle estimate off by 2.7-fold (0.43 log units), on the high side, outside the stated range (below it).
By their numbers in this assay, from the lowest: compound 3; then compound 2; then compound 1.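

In this assay, methyl in place of hydrogen on an aromatic carbon, para to a large group, gives a 2.3-fold lower number from compound 2 to compound 3 (0.37 log units; beyond the scatter), so this position answers to a single added carbon. With that methyl present, 2-aminophenyl in place of hydroxy on an amide-type nitrogen gives a 39-fold lower number from compound 1 to compound 3 (1.59 log units; beyond the scatter), a large step. No measurement shown bears on the reason for either step. As far as these compounds go, whether a methoxy group, a chlorine atom or an ethyl group at this position would move the number as methyl does remains open.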